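A few compounds are considered here, and "the series" means these few. Any claim that something is new, unique, unknown or untested is made for them only; others in the source may bear on it.

Measured compounds and their values: compound 1 `COc1ccc(C2=C(CN3CCN(c4ccc(C(=O)NS(=O)(=O)c5ccc(NCC6CCOCC6)c([N+](=O)[O-])c5)c(Oc5cnc6[nH]ccc6c5)c4)CC3)CCC(C)(C)C2)cc1` gives 3.8 nM in an assay on isolated protein for displacement of a labelled ligand from Apoptosis regulator Bcl-2 (Homo sapiens), with a stated time of 15 min; on this read-out lower numbers stand for stronger inhibition and higher numbers for weaker inhibition; compound 2 `CC1(C)CCC(CN2CCN(c3ccc(C(=O)NS(=O)(=O)c4ccc(NCC5CCOCC5)c([N+](=O)[O-])c4)c(Oc4cnc5[nH]ccc5c4)c3)CC2)=C(c2ccc(C(F)(F)F)c(Cl)c2)C1` gives 0.8 nM; compound 3 `CCN(CC)CCCNc1ccc(S(=O)(=O)NC(=O)c2ccc(N3CCN(CC4=C(c5ccc(C(F)(F)F)cc5)CC(C)(C)CC4)CC3)cc2Oc2cnc3[nH]ccc3c2)cc1[N+](=O)[O-]` gives 0.3 nM.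

Compound 3 gives the lowest of the three numbers, with compound 2 nearest and compound 1 furthest. Compound 4 `CC1(C)CCC(CN2CCN(c3ccc(C(=O)NS(=O)(=O)c4ccc(OCC5CCSCC5)c([N+](=O)[O-])c4)c(Oc4cnc5[nH]ccc5c4)c3)CC2)=C(c2ccc(C(F)(F)F)cc2)C1` differs from compound 3 by a group of 8 heavy atoms (6 carbon, 1 oxygen, 1 sulfur; one six-membered non-aromatic ring with 1 hetero atom) in place of a group of 9 heavy atoms (7 carbon, 2 nitrogen; no ring), on an aromatic carbon. Among the measured compounds shown here, the only measured step, a 4.8-fold lower number from compound 1 to compound 2 (0.68 log units; beyond the scatter), concerns the aryl group on the double-bonded ring carbon and does not bear on this change; compound 1 and compound 3 differ in two places, so their gap cannot be read for it alone. For the measured compounds named here, with no direct precedent, a small weakening is expected, a 3.3-fold higher number from compound 3 to compound 4 (0.52 log units; beyond the scatter), giving an estimated value for compound 4 of 1 nM, within 0.3 nM to 4 nM.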

Compound 4, half-maximal inhibitory concentration: 1.65 nM
The estimate for compound 4 lay 1.7-fold (0.22 log units) below the measured number; the measured number falls inside the stated range.
By their numbers in this assay, from the lowest: compound 3; then compound 2; then compound 4; then compound 1.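

In this assay, replacing the (3-(diethylamino)propyl)amino group on this aromatic carbon, ortho to the nitro group, with the sulfur-containing ring group gives a 5.5-fold higher number from compound 3 to compound 4 (0.74 log units; beyond the scatter). The position therefore accepts a ring group with no hydrogen-bond donor in place of an open chain carrying one, at a modest cost that is beyond the scatter. Nothing available accounts for the size of this step.

Because the linking atom, ring and chain all change together, the compounds shown do not separate their contributions. On these data alone, how a carboxylic acid or a longer diethylamino chain on this carbon would read also stays open.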